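Isobutyl Amide in Place of Phenylcyclopentyl Amide

The source may hold more compounds than are shown below. What is called first, only, known or untested is meant among the compounds shown, and "the series" means these compounds.

Compound 2 `NCCNc1cc(N2CCN(C(=O)C3(c4ccccc4)CCCC3)CC2)nc2ccccc12` is reported in an ADME assay on HEp-2 cells (Homo sapiens) for cytotoxicity, read by CCK-8 assay, with a stated time of 6 days (on this read-out lower numbers stand for higher toxicity in this test and higher numbers for lower toxicity in this test), only as a limit, > 100000 nM, and the limit of > 100000 nM in this assay, at which 1 of the 2 values shown sits, marks that boundary rather than a measured number. Compound 1 `NCCNc1cc(N2CCN(c3ccccc3)CC2)nc2ccccc12` gives 20800 nM in this assay. Compound 3 `CC(C)CC(=O)N1CCN(c2cc(NCCN)c3ccccc3n2)CC1` differs from compound 2 by isobutyl in place of 1-phenylcyclopentyl on a carbonyl carbon. Among the compounds with values here, no measured step of this kind is available, so a shift beyond the usual scatter is not anticipated in either direction. Compound 3 is therefore expected to give 100000 nM, with a likely span from 30000 nM to 300000 nM. The expected step of a number no higher from compound 2 to compound 3 (the limit leaves the size open) is accordingly small, and the result may again come back as a limit.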

Compound 3, half-maximal cytotoxic concentration: > 100000 nM
Compound 3 ended at the assay's limit; the forecaster's own chance of this, stated with the estimate: 60%; the middle value sits exactly at the limit.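

The step from compound 2 to compound 3 cannot be read, as both values are the same limit: the limit of > 100000 nM in this assay, at which 2 of the 3 values shown sit.

Compound 3 does show that the ringed 1-phenylcyclopentyl is not needed to reach that limit, since isobutyl, with no ring, on the same carbonyl carbon reaches it too. Isobutylcarbonyl in place of phenyl on an amine nitrogen in a ring gives an at least 4.8-fold higher number from compound 1 to compound 3 (0.68 log units; beyond the scatter) in this assay.

From the compounds shown here alone, it remains open where either amide truly lies beyond the limit. Also open, going by these compounds, is whether an amine, a carboxylic acid or a longer chain on that carbonyl carbon would bring the number back within the measurable range.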